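Glycine ester in place of the arginine side chain

The source may hold more compounds than are shown below. What is called first, only, known or untested is meant among the compounds shown, and "the series" means these compounds.

Three compounds were tested in a functional assay on the whole organism (Tail, strain ICR) with Mus musculus as the target, in the tail flick test, with a stated time of 90 min, at a dose of 25 umol/kg by the oral route; on this read-out higher numbers stand for a stronger effect at the one dose given and lower numbers for a weaker effect. Compound 1, `O=C(O)[C@@H]1CCCN1C(=O)CN(c1nc(Cl)nc2[nH]cnc12)C1CC1`, gives 26% in this assay. Compound 2, `O=C(CN(c1ncnc2c1ncn2C1CCCCO1)C1CC1)N[C@@H](CO)C(=O)OCc1ccccc1`, gives 32.2%. Compound 3, `N=C(N)NCCC[C@H](NC(=O)CN(c1nc(Cl)nc2[nH]cnc12)C1CC1)C(=O)OCc1ccccc1`, gives 30.4%. The three numbers lie close together: the value of compound 3 differs from that of compound 2 and from that of compound 1 by amounts that fall within the scatter of repeated measurements, so the three compounds cannot be told apart on these numbers.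

Compound 4, `O=C(CN(c1nc(Cl)nc2[nH]cnc12)C1CC1)NCC(=O)OCc1ccccc1`, has not yet been measured. It differs from compound 3 in one place: a hydrogen atom in place of a group of 7 heavy atoms (4 carbon, 3 nitrogen; no ring), on a saturated chain carbon bound to an amide-type nitrogen and a carbonyl carbon.

Since compounds 1, 2 and 3 carry different substituents at the corresponding carbon and still give values within the scatter of one another, a change at this carbon is expected to leave the read-out in this assay where it stands. The step from compound 3 to compound 4 is therefore expected to be a number 2.4 percentage points lower from compound 3 to compound 4 (within the scatter), that is, no change beyond the scatter. For compound 4 in this assay the estimate is 28%, with a range from 14% to 42%.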

Compound 4, a percentage reported as activity, at one dose (the size of the read-out at that dose, not a potency): 27.2%
Compound 4: middle estimate off by 0.8 percentage points, on the high side; the range from low to high includes it.
By their numbers in this assay, from the lowest: compounds 1, 4, 3 and 2 (each within the scatter of the next).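

In this assay, replacing the whole group of 7 heavy atoms (4 carbon, 3 nitrogen; no ring) with a hydrogen atom, on a saturated chain carbon bound to an amide-type nitrogen and a carbonyl carbon, gives a number 3.2 percentage points lower from compound 3 to compound 4 (within the scatter). Within the data shown here, this pair is the only one here that differs in one place, so it gives the first direct reading at this carbon, where the earlier compounds differed in several places at once: the read-out stays within the scatter when this group leaves, along with its 3 hydrogen-bond donors and its double bond, and so at this one dose the group is not required for the read-out seen with compound 3. No accompanying measurement bears on why the read-out holds when the group is removed.

What the compounds shown leave open is whether a small group at this carbon, such as a methyl group, or a longer chain ending in an amine, would move the read-out beyond the scatter. From the compounds shown here alone, it also remains open whether compound 3 and compound 4 would separate at other doses, since a read-out at a single dose is not a potency.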